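Removing a Methyl on the Benzylsulfanyl Arm: Compound 4

This account rests on a few compounds, and the source may have more. Where it says the series, first, only, none or still open, it means among the compounds named here.

Of the compounds shown here, three sharing one core have been measured in a functional assay on HeLa cells (Homo sapiens) for cytotoxicity, read by MTT assay, with a stated time of 72 h; a higher number here means a weaker inhibitor, a lower number a stronger inhibitor. Compound 1 `Cc1cc(-c2ccccc2)n(/C(N)=N/S(=O)(=O)c2cc(C)c(Cl)cc2SCc2ccc(C(F)(F)F)cc2)n1` gives 19000 nM. Compound 3 `Cc1cc(S(=O)(=O)/N=C(\N)n2nccc2-c2ccccc2)c(SCc2ccc(C(F)(F)F)cc2)cc1Cl` gives 17000 nM. Compound 2 `Cc1cccc(CSc2cc(Cl)c(C)cc2S(=O)(=O)/N=C(\N)n2nc(C)cc2-c2ccccc2)c1` gives 155000 nM, the highest of the three numbers.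

Compound 2 differs from compound 1 by 3-methylphenyl in place of 4-(trifluoromethyl)phenyl on a saturated chain carbon bound to a sulfur. That change gave an 8.2-fold higher number from compound 1 to compound 2 (0.91 log units; beyond the scatter). Compound 3 differs from compound 1 by hydrogen in place of methyl on an aromatic carbon, and that step was a 1.1-fold lower number from compound 1 to compound 3 (0.05 log units; within the scatter).

Compound 4 `Cc1cc(-c2ccccc2)n(/C(N)=N/S(=O)(=O)c2cc(C)c(Cl)cc2SCc2ccccc2)n1` has not yet been measured. It differs from compound 2 by hydrogen in place of methyl on an aromatic carbon. Among the compounds with values here, this is the same kind of change as the one from compound 1 to compound 3, not the same change: there it was made on an aromatic carbon of a five-membered aromatic ring with 2 nitrogen, next to the ring nitrogen, two ring bonds from the ring atom that bears a phenyl group; here it is made on an aromatic carbon of a six-membered aromatic ring of carbon only, meta to a large group.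

Because a 1.1-fold lower number from compound 1 to compound 3 (0.05 log units; within the scatter) lay within the scatter, the step from compound 2 to compound 4 in this assay is expected to be small as well, a 1.2-fold lower number from compound 2 to compound 4 (0.08 log units; within the scatter). Within the data shown here, none of the measured compounds shows what happens when a methyl is taken off the benzyl arm, so this expectation rests on one earlier step made elsewhere in the molecule. Compound 4 is therefore estimated at 130000 nM in this assay, with a likely range from 50000 nM to 350000 nM.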

Compound 4, half-maximal inhibitory concentration: 5000 nM
Beside the measured number, compound 4's estimate is 26-fold (1.41 log units) above it; measured number outside the range, below it.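

In this assay, hydrogen in place of methyl on an aromatic carbon did not carry over as one transferable change between the two places where it was made: the same change on two cores in this assay, a 1.1-fold lower number (0.05 log units; within the scatter) from compound 1 to compound 3 and a 31-fold lower number (1.49 log units; beyond the scatter) from compound 2 to compound 4, 28-fold (1.44 log units) apart, beyond the scatter of two such steps

On the benzyl arm, the loss of the methyl gave a 31-fold lower number from compound 2 to compound 4 (1.49 log units; beyond the scatter), and hydrogen in place of trifluoromethyl gave a 3.8-fold lower number from compound 1 to compound 4 (0.58 log units; beyond the scatter), so among these three compounds, each substituted benzyl arm gives a higher number than the plain benzyl arm of compound 4. The comparison does not show why the two methyl steps part: the methyl leaves a different ring in each, and one pair of steps cannot separate the place of the change from the core that carries it.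

Left open is how the number would respond to other groups on the phenyl ring of the benzylsulfanyl arm, such as a chlorine, a fluorine or a methoxy group, in place of the methyl or the trifluoromethyl. Also open, going by these compounds, is whether taking the methyl off the five-membered ring would remain as small a step on the core of compound 2 or compound 4 as it was on the core of compound 1.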